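The compounds below may be only part of what the source reports. "The series", "measured", "known", "first", "only" and "open" are said of these compounds alone.

This study measured a small set of compounds in a functional assay on L1210 cells (Mus musculus), read by cell counting, with a stated time of 48 h; on this read-out lower numbers stand for stronger inhibition and higher numbers for weaker inhibition. Compound 1 `Fc1ccc(/N=C/c2ccccc2Cl)cc1Cl` and compound 2 `Clc1ccccc1/C=N/c1ccc(Br)cc1` both carry an imine link between two aromatic rings. In this assay compound 1 gives 6.4 ug/mL. In this assay compound 2 gives 2.1 ug/mL. Compound 3 `COc1ccc(/C=C/c2ccc(C)cc2)cc1` instead has a carbon-carbon double bond joining its two rings. For compound 3 the assay reports only a limit, > 200 ug/mL, and not a number; this is the limit of > 200 ug/mL in this assay, at which 1 of the 3 values shown sits. Compound 3 therefore stands apart from the two compounds that gave a number.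

Compound 4 `Cc1ccc(/C=C/c2ccc(N(C)C)cc2)cc1` is not yet measured. Among the compounds with values here, its only difference from compound 3 is dimethylamino in place of methoxy on an aromatic carbon. Within the data shown here, no measured pair in this set shares that change, so there is no direct comparison to lean on. Because compound 3 sits at the limit of > 200 ug/mL in this assay, at which 1 of the 3 values shown sits, any gain for compound 4 would need to be substantial before a number appears. The expected step is an at least 2.0-fold lower number from compound 3 to compound 4 (0.30 log units; that floor lies within the scatter), towards stronger inhibition but of uncertain size. Compound 4 is expected to give about 100 ug/mL in this assay, within a range from 20 ug/mL to 200 ug/mL.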

Compound 4, half-maximal inhibitory concentration: 143 ug/mL
The estimate for compound 4 lay 1.4-fold (0.16 log units) below the measured number; the measured number falls inside the stated range.
By their numbers in this assay, from the lowest: compound 2; then compound 1; then compound 4. At a limit, above all of these: compound 3.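

In this assay, within the data shown here, compound 4 is the first compound with a carbon-carbon double bond joining its two rings to give a number and not a limit. On this aromatic carbon, dimethylamino in place of methoxy comes with an at least 1.3-fold lower number from compound 3 to compound 4 (0.14 log units; that floor lies within the scatter). The change may therefore be small or much larger, and its true size stays unknown because compound 3 has only a limit and no number of its own: the limit of > 200 ug/mL in this assay, at which 1 of the 4 values shown sits.

On these data alone, whether a primary amine or a hydroxyl group on this same aromatic carbon would give a lower number stays open, as does the effect of a longer chain such as ethoxy. The compounds shown also contain no pair that compares the imine link directly with the carbon-carbon double bond while everything else stays the same.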